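A few compounds are considered here, and "the series" means these few. Any claim that something is new, unique, unknown or untested is made for them only; others in the source may bear on it.

For the measured compounds named here, in a functional assay on HL-60 cells (Homo sapiens) for cytotoxicity, read by luminescence and CellTiter-Glo, with a stated time of 3 days (on this read-out lower numbers stand for stronger inhibition and higher numbers for weaker inhibition), three related compounds have numbers so far: compound 1 (`N#Cc1ccc(NC(=O)c2cc(-c3ccccc3)ccc2O)cc1`) gives 1350 nM and compound 2 (`Cc1ccc(C(=O)Nc2ccc(C#N)cc2)c(O)c1`) gives 2420 nM while compound 3 (`N#Cc1ccc(NC(=O)c2ccc3ccccc3c2O)cc1`) gives 3410 nM as its number. The number for compound 2 lies within the usual scatter of each of the other two, so it cannot be ranked against either of them. Compound 4 (`N#Cc1ccc(NC(=O)c2ccc(C(F)(F)F)cc2O)cc1`) is compound 2 with one change, trifluoromethyl in place of methyl on an aromatic carbon that is meta to a hydroxy group and para to a large group. Going by the values given here, no two measured compounds differ in only one place, so there is no direct guide to the size of this step. Still, compound 1 at 1350 nM and compound 3 at 3410 nM stay within the scatter of compound 2 although their structures differ from it by more than this swap. The expected result is a 1.3-fold lower number from compound 2 to compound 4 (0.13 log units; within the scatter) as an estimate, a step that stays within the scatter. In this assay the estimated value for compound 4 is 1800 nM (expected range 600 nM to 5000 nM).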

Compound 4, half-maximal inhibitory concentration: 1030 nM
For compound 4 the middle estimate is 1.7-fold (0.24 log units) above the measured one; the measured number falls inside the stated range.
By their numbers in this assay, from the lowest: compounds 4, 1, 2 and 3 (each within the scatter of the next, the first and the last beyond it).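

In this assay, for the compounds shown here, this pair gives the only comparison of compounds that differ in one place: trifluoromethyl in place of methyl, on the aromatic carbon that is meta to a hydroxy group and para to a large group, gives a 2.3-fold lower number from compound 2 to compound 4 (0.37 log units; beyond the scatter) and is the first clear sign that a change here can shift the number. Going by these compounds alone, the step is modest, but it shows that this carbon accepts the bigger trifluoromethyl group with no rise in the number, something the earlier compounds, which differ from each other in more than one place, could not show. Nothing measured here explains why the number moves.

A single pair cannot set a trend for this position. As far as these compounds go, how a chlorine atom, a methoxy group or an amine on the same carbon would compare remains open, as does the size of this same swap on another carbon of the ring.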